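The source may hold more compounds than are shown below. What is called first, only, known or untested is meant among the compounds shown, and "the series" means these compounds.

Compound 1 `O=CN(C1CCCC1)C1CC1` gives the lower of the two numbers recorded in an assay on isolated protein for inhibition of all-trans-retinol dehydrogenase [NAD(+)] ADH4 (Homo sapiens) (on this read-out lower numbers stand for stronger inhibition and higher numbers for weaker inhibition), with compound 1 at 96000 nM and compound 2 `CC(C)CNC=O` at 340000 nM in this assay. From compound 1 the step to compound 3 `O=CN(C1CCCC1)C1CCC1` is cyclobutyl in place of cyclopropyl on an amide-type nitrogen, a change that adds a single carbon to the ring on the nitrogen. Going by the values given here, nothing measured so far shows how this assay responds to such a ring enlargement, so the step is expected to stay within the usual scatter, with no clear direction. Compound 3 is therefore estimated at 85000 nM, between 30000 nM and 250000 nM, a step of a 1.1-fold lower number from compound 1 to compound 3 (0.05 log units; within the scatter).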

Compound 3, inhibition constant: 360000 nM
Compound 3: the middle estimate sits 4.2-fold (0.63 log units) below what was measured; the measured number lies above the stated range.
By their numbers in this assay, from the lowest: compound 1; then compounds 2 and 3 (each within the scatter of the next).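

In this assay, this position on the amide-type nitrogen is sensitive to ring size: cyclobutyl in place of cyclopropyl gives a 3.8-fold higher number from compound 1 to compound 3 (0.57 log units; beyond the scatter) and so weakens inhibition beyond the scatter. The earlier compounds shown here could not show this, as they offered no step at this place. Nothing available accounts for this loss. The compounds shown leave open whether smaller groups on this nitrogen, such as methyl or ethyl, would match cyclopropyl. They also leave open how a larger ring such as cyclohexyl or an open isopropyl group would read here.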